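The compounds below may be only part of what the source reports. "The series", "measured", "known", "first", "only" and "open" are said of these compounds alone.

Compound 1 `CCCCCCCCCCC#Cc1cc2cn([C@@H]3O[C@H](CO)[C@@H](O)[C@@H]3O)c(=O)nc2o1` is the parent of this set. In a functional assay on HEL cells (Homo sapiens) for cytotoxicity (a higher number here means that more compound is tolerated, a lower number that less compound is tolerated), compound 1 gives 46000 nM, the highest of the three numbers measured. Compound 2 `CCCCCCCCCCC#Cc1cc2cn([C@H]3C[C@H](O)[C@@H](CO)O3)c(=O)nc2o1`, with hydrogen in place of hydroxy on a saturated ring carbon, gives 30000 nM, and the step of a 1.5-fold lower number from compound 1 to compound 2 (0.19 log units; within the scatter) stays within the scatter. Compound 3 `CCCCCCCCCCC#Cc1cc2cn([C@@H]3O[C@H](CO)[C@@H](O)[C@H]3O)c(=O)nc2o1` gives 12000 nM; the step of a 3.8-fold lower number from compound 1 to compound 3 (0.58 log units; beyond the scatter) is modest, and it rests on (the fact that compounds 1 and 3 differ only in the configuration as drawn). From compound 2 to compound 3 the hydroxy returns on a saturated ring carbon, and a 2.5-fold lower number from compound 2 to compound 3 (0.40 log units; beyond the scatter) is again modest.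

Compound 4 `CCCCCCCCC#Cc1cc2cn([C@@H]3O[C@H](CO)[C@@H](O)[C@@H]3O)c(=O)nc2o1` is not yet measured. Its change from compound 1 is hydrogen in place of ethyl on a saturated chain carbon, eight bonds along the chain from a triple-bonded carbon. Going by the values given here, none of the measured steps touches the chain: all three concern the sugar ring, either the hydroxy on a saturated ring carbon or the configuration at a saturated ring carbon. Among the compounds with values here, no step therefore bears directly on the shortening of the chain, and the steps within the ring give no guide in either direction for it.

Without a relevant precedent, compound 4 is expected to stay close to compound 1, with a step of no change at the digits printed from compound 1 to compound 4 (within the scatter) that is not expected to go beyond the scatter. For compound 4 the estimate in this assay is 46000 nM, with a range from 18000 nM to 120000 nM.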

Compound 4, minimum cytotoxic concentration: 49000 nM
Estimate against measurement, compound 4: 1.1-fold (0.03 log units) below, within the range that was stated.
By their numbers in this assay, from the lowest: compound 3; then compounds 2, 1 and 4 (each within the scatter of the next).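

In this assay, hydrogen in place of ethyl on a saturated chain carbon, eight bonds along the chain from a triple-bonded carbon, gives a 1.1-fold higher number from compound 1 to compound 4 (0.03 log units; within the scatter). Going by these compounds alone, all earlier steps lay in the saturated ring, so this is the first reading from the chain, and it shows that removing these two carbons leaves the cytotoxicity read-out indistinguishable from that of compound 1, whereas the configuration step from compound 1 to compound 3 and the hydroxy step from compound 2 to compound 3 both went beyond the scatter. Nothing given here accounts for this result, since the only supporting fact concerns the configuration shared by no pair other than compounds 1 and 3 and has no bearing on the chain.

The compounds shown leave open whether a longer chain, a much shorter one such as propyl, or an amine or a carboxylic acid on that same saturated chain carbon would also stay within the scatter of compound 1. They also leave open whether the same chain change would behave alike on the ring of compound 2 or compound 3, and how any of these compounds reads outside this cytotoxicity measure.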